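The source may report more compounds than this note shows. Statements on the series, on what has been measured and on what is new or still open speak of the compounds shown alone.

Of the compounds shown here, three share a sulfonamide-linked cinnamamide framework and have been tested in a functional assay on B16-F10 cells (Mus musculus) for antiproliferative activity, read by ELISA and MTT assay, with a stated time of 48 h; a higher number here means a weaker inhibitor, a lower number a stronger inhibitor. Compound 1 `O=C(/C=C/c1ccc(F)cc1)NS(=O)(=O)c1ccccc1` gives 2.1 ug/mL in this assay. Compound 2 `Cc1ccc(S(=O)(=O)NC(=O)/C=C/c2ccc(F)cc2)cc1` differs from compound 1 by methyl in place of hydrogen on an aromatic carbon; in this assay compound 2 gives 4.8 ug/mL, so the step of a 2.3-fold higher number from compound 1 to compound 2 (0.36 log units; beyond the scatter) weakens inhibition by a modest amount. Compound 3 `O=C(/C=C/c1ccccc1[N+](=O)[O-])NS(=O)(=O)c1ccccc1` carries a different substituted aryl group on the cinnamoyl side; the difference between the core of compound 1 and the core of compound 3 is not broken down here. In this assay compound 3 gives 6 ug/mL, a number that sits within the usual scatter of the value of compound 2 and beyond the scatter above the value of compound 1.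

Compound 4 `Cc1ccc(S(=O)(=O)NC(=O)/C=C/c2ccccc2[N+](=O)[O-])cc1` has not yet been measured. It differs from compound 3 by methyl in place of hydrogen on an aromatic carbon, the same change that separates compound 2 from compound 1, made on the same kind of position. For the measured compounds named here, because the only precedent for this change is a 2.3-fold higher number from compound 1 to compound 2 (0.36 log units; beyond the scatter), the expected step of a 2.0-fold higher number from compound 3 to compound 4 (0.30 log units; within the scatter) is taken to be of similar size and in the same direction, with the reservation that a single observed step on a different core gives a thin basis. Compound 4 is therefore expected to give 12 ug/mL in this assay. For compound 4 the range is estimated to run from 5 ug/mL to 28 ug/mL.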

Compound 4, half-maximal inhibitory concentration: 10.3 ug/mL
The estimate for compound 4 lay 1.2-fold (0.07 log units) above the measured number; the measured number falls inside the stated range.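

In this assay, methyl in place of hydrogen on an aromatic carbon gives a 1.7-fold higher number from compound 3 to compound 4 (0.23 log units; within the scatter), and set beside the earlier step on the other core, the two cannot be told apart: the same change on two cores in this assay, a 2.3-fold higher number (0.36 log units; beyond the scatter) from compound 1 to compound 2 and a 1.7-fold higher number (0.23 log units; within the scatter) from compound 3 to compound 4, 1.3-fold (0.12 log units) apart, within the scatter of two such steps. The change therefore carries over from the core of compound 1 to the core of compound 3 with a size that stays within the scatter of the first, and both steps point the same way, although the new step taken alone does not clear the scatter. For the compounds shown here, this is no general rule, for it rests on only two pairs, both phenyl to 4-methylphenyl, one on a core carrying fluorine and one on a core carrying a nitro group, and it says nothing about why the steps have the size they do.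

The compounds shown leave open whether phenyl to 4-methylphenyl behaves alike on a cinnamoyl side carrying a methoxy group, an amine or a carboxylic acid. They also leave open what a chlorine or a longer alkyl chain in place of the methyl would give on either core.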